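This account rests on a few compounds, and the source may have more. Where it says the series, first, only, none or still open, it means among the compounds named here.

Three compounds from this series share a five-membered aromatic core carrying a nitrile and an imine link to a second benzene ring, and all three have been tested in a functional assay on MCF7 cells (Homo sapiens) for antiproliferative activity, read by MTT assay, with a stated time of 48 h; a lower number here means a stronger inhibitor, a higher number a weaker inhibitor. Compound 1, `N#Cc1ncn(-c2ccc(F)cc2)c1/N=C/c1ccc([N+](=O)[O-])cc1`, gives 9100 nM in this assay. Compound 2, `COc1ccc(/C=N/c2c(C#N)ncn2-c2ccc(F)cc2)cc1`, gives 9330 nM in this assay. Compound 3, `N#Cc1ncn(Cc2ccc(F)cc2)c1/N=C/c1ccc([N+](=O)[O-])cc1`, gives 10600 nM in this assay. The three numbers sit close to one another, all within the usual scatter of such measurements.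

Compound 2 arises from compound 1 through (methoxy in place of nitro on an aromatic carbon), and this change gives a 1.0-fold higher number from compound 1 to compound 2 (0.01 log units; within the scatter). Compound 3 arises from compound 1 through a change at the core, (4-fluorobenzyl in place of 4-fluorophenyl on an aromatic nitrogen), which gives a 1.2-fold higher number from compound 1 to compound 3 (0.07 log units; within the scatter).

The unmeasured compound 4, `COc1ccc(/C=N/c2c(C#N)ncn2Cc2ccc(F)cc2)cc1`, arises from compound 3 through (methoxy in place of nitro on an aromatic carbon). Going by the values given here, the change is described in the same words, at the same place, as the one from compound 1 to compound 2, so it is the same change made on the other core. Since that earlier change gave a 1.0-fold higher number from compound 1 to compound 2 (0.01 log units; within the scatter), the expectation for compound 4 is a step of a 1.0-fold higher number from compound 3 to compound 4 (0.01 log units; within the scatter) from compound 3 in this assay, again inside the scatter. Compound 4 is therefore estimated to give about 10900 nM in this assay, with a likely range from 5500 nM to 21000 nM, the width of the range reflecting only the ordinary spread of repeated measurements.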

Compound 4, half-maximal inhibitory concentration: 3870 nM
Estimate against measurement, compound 4: 2.8-fold (0.45 log units) above; measured number below the stated range.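

In this assay, methoxy in place of nitro on an aromatic carbon gives a 2.7-fold lower number from compound 3 to compound 4 (0.44 log units; beyond the scatter), so the swap that made no clear difference on the core of compound 1 does not behave the same way on the core of compound 3: the same change on two cores in this assay, a 1.0-fold higher number (0.01 log units; within the scatter) from compound 1 to compound 2 and a 2.7-fold lower number (0.44 log units; beyond the scatter) from compound 3 to compound 4, 2.8-fold (0.45 log units) apart, beyond the scatter of two such steps. Read the other way round, 4-fluorobenzyl in place of 4-fluorophenyl on an aromatic nitrogen gives a 2.4-fold lower number from compound 2 to compound 4 (0.38 log units; beyond the scatter), and this too departs from the step seen with the nitro group in place: the same change on two cores in this assay, a 1.2-fold higher number (0.07 log units; within the scatter) from compound 1 to compound 3 and a 2.4-fold lower number (0.38 log units; beyond the scatter) from compound 2 to compound 4, 2.8-fold (0.45 log units) apart, beyond the scatter of two such steps. This shows that in these compounds the two changes do not act independently, so a step measured on one core cannot simply be carried to the other; however, both comparisons rest on the same four compounds in a single assay, so they count as one observation, and they show neither why the steps differ nor whether the same holds elsewhere in the series.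

The compounds shown leave open whether other groups in place of nitro or methoxy, such as an amine or a carboxylic acid, would also depend on the group on the aromatic nitrogen. They also leave open what a longer chain on that nitrogen would do to either step.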